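The source may report more compounds than this note shows. Statements on the series, on what has been measured and on what is new or still open speak of the compounds shown alone.

Compound 1 `C=CC1=C(C(=O)Nc2ccccc2)C(c2ccc(Cl)c(Cl)c2)OC1` gives > 100000 nM in a functional assay on SW480 cells (Homo sapiens) for cytotoxicity, read by MTT assay, with a stated time of 24 h (on this read-out lower numbers stand for stronger inhibition and higher numbers for weaker inhibition), a value that is a limit of the assay and not a number. Compound 2 `C=CC1=C(C(=O)Nc2ccccc2OC)C(c2ccc(F)cc2)OC1` gives > 100000 nM, likewise a limit. Compound 3 `C=CC1=C(C(=O)NCc2ccc(C)cc2)C(c2ccc(F)cc2)OC1` gives > 100000 nM, again a limit.

Compound 3 therefore stands at the limit together with both other measured compounds, the whole set sitting at the limit of > 100000 nM in this assay, at which 3 of the 3 values shown sit. For the measured compounds named here, the single step between measured compounds, a step that the two limits leave unreadable from compound 2 to compound 3, cannot be sized because the limit of > 100000 nM in this assay, at which 3 of the 3 values shown sit, hides both ends. Compound 4 `C=CC1=C(C(=O)Nc2ccccc2)C(c2ccc(F)cc2)OC1` differs from compound 3 by phenyl in place of 4-methylbenzyl on an amide-type nitrogen. Compound 1 also carries phenyl on an amide-type nitrogen and sits at the limit. No readable step bears on this change, so no shift beyond the scatter is expected. Compound 4 is estimated at 150000 nM, within 100000 nM to 400000 nM. The step this estimate means, a step that the limit leaves unreadable from compound 3 to compound 4, is expected to stay unreadable as well.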

Compound 4, half-maximal inhibitory concentration: > 100000 nM
Compound 4 gave a limit, no number; the forecaster's own chance of this, stated with the estimate: 85%; the middle value does not contradict the limit.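

Compound 4, like compound 1, compound 2 and compound 3, gives only a limit, so no step among these compounds can be read: the limit of > 100000 nM in this assay, at which 4 of the 4 values shown sit. The compounds shown leave open which change on the amide-type nitrogen or the saturated ring carbon, if any, would give a readable value.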